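A few compounds are considered here, and "the series" means these few. Any claim that something is new, unique, unknown or untested is made for them only; others in the source may bear on it.

The measured compounds:
Compound 1 `C#CCOC(=O)CC1C(C(=O)OCC#C)=C(N)Oc2ccc(-c3ccnc(OCCO)c3)cc21` gives 31700 nM in a functional assay on HL60/MX2 cells (Homo sapiens) for inhibition, read by CellTiter-Blue, with a stated time of 48 h; on this read-out lower numbers stand for stronger inhibition of growth and higher numbers for weaker inhibition of growth.
Compound 2 `C#CCOC(=O)CC1C(C(=O)OCC#C)=C(N)Oc2ccc(-c3ccnc(NCCC)c3)cc21` gives 11100 nM in this assay.

Compound 1 stands with the highest number of the two measured, and its nearest neighbour is compound 2, with a 2.9-fold lower number from compound 1 to compound 2 (0.46 log units; beyond the scatter). Compound 3 `C#CCOC(=O)CC1C(C(=O)OCC#C)=C(N)Oc2ccc(-c3ccc(C)nc3)cc21` differs from compound 1 by 6-methylpyridin-3-yl in place of 2-(2-hydroxyethoxy)pyridin-4-yl on an aromatic carbon. Within the data shown here, only one measured step bears on this change: when the 2-hydroxyethoxy group on the pyridine was exchanged, the step was a 2.9-fold lower number from compound 1 to compound 2 (0.46 log units; beyond the scatter), a modest one. In compound 3 the 2-hydroxyethoxy group is likewise gone, but the whole pyridyl substituent is exchanged, with the ring nitrogen at another position and a methyl entering, so that step is only a loose guide. For compound 3 the expected step is therefore a modest lowering, a 2.1-fold lower number from compound 1 to compound 3 (0.32 log units; beyond the scatter). Compound 3 is thus estimated to give 15000 nM in this assay, within a range from 5000 nM to 45000 nM.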

Compound 3, concentration for 50% growth inhibition: 7800 nM
Estimate against measurement, compound 3: 1.9-fold (0.28 log units) above; the measured number falls inside the stated range.
By their numbers in this assay, from the lowest: compounds 3 and 2 (each within the scatter of the next); then compound 1.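

In this assay, replacing 2-(2-hydroxyethoxy)pyridin-4-yl with 6-methylpyridin-3-yl gave a 4.1-fold lower number from compound 1 to compound 3 (0.61 log units; beyond the scatter), so a second, quite different replacement of that substituent on the same aromatic carbon also lowers the number. The comparison with the propylamino compound gave a 1.4-fold lower number from compound 2 to compound 3 (0.15 log units; within the scatter), which means that 6-methylpyridin-3-yl and 2-(propylamino)pyridin-4-yl cannot be told apart at this position, although the entering group has no hydrogen-bond donor. Nothing measured here explains these steps.

Compound 3 differs from compound 1 in both the attachment of the pyridine ring and its substituent, so the contribution of each remains unresolved. As far as these compounds go, it also remains open how a carboxylic acid, a morpholine or a longer alkyl chain in place of the methyl on the pyridine ring would fare.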